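A Methyl-to-Hydrogen Swap Repeated on a Second Scaffold

The source may hold more compounds than are shown below. What is called first, only, known or untested is meant among the compounds shown, and "the series" means these compounds.

Measured in a functional assay on PANC-1 cells (Homo sapiens) for inhibition, read by MTT assay, with a stated time of 48 h; a higher number here means a weaker inhibitor, a lower number a stronger inhibitor:
Compound 1, `C/C(=N/O)c1ccc(NC(=O)CSc2nc3c([nH]2)c(=O)n(C)c(=O)n3C)cc1`: 4600 nM
Compound 2, `C/C(=N/O)c1ccc(NC(=O)CSc2nc3[nH]c(=O)n(C)c(=O)c3[nH]2)cc1`: 7700 nM
Compound 3, `Cn1c(=O)c2[nH]c(SCC(=O)c3ccccc3)nc2n(C)c1=O`: 4900 nM

Compound 2 differs from compound 1 only by hydrogen in place of methyl on an aromatic nitrogen, and in this assay that step is a 1.7-fold higher number from compound 1 to compound 2 (0.22 log units; within the scatter). Compound 3 carries a different side chain; the difference between its core and the core of compound 1 is not broken down here, and its value sits within the scatter of both compound 1 and compound 2. Compound 4, `Cn1c(=O)[nH]c2nc(SCC(=O)c3ccccc3)[nH]c2c1=O`, is not yet measured and differs from compound 3 by hydrogen in place of methyl on an aromatic nitrogen, the same change as between compound 1 and compound 2. The step from compound 3 to compound 4 in this assay is expected to be about a 1.5-fold higher number from compound 3 to compound 4 (0.18 log units; within the scatter), because the measured precedent is a 1.7-fold higher number from compound 1 to compound 2 (0.22 log units; within the scatter). Compound 4 is therefore estimated at 7500 nM, most likely between 3500 nM and 16000 nM.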

Compound 4, half-maximal inhibitory concentration: 9400 nM
The estimate for compound 4 lay 1.3-fold (0.10 log units) below the measured number; the measured number falls inside the stated range.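

In this assay, hydrogen in place of methyl on an aromatic nitrogen gives a 1.9-fold higher number from compound 3 to compound 4 (0.28 log units; within the scatter). Set beside the earlier step, the two agree: the same change on two cores in this assay, a 1.7-fold higher number (0.22 log units; within the scatter) from compound 1 to compound 2 and a 1.9-fold higher number (0.28 log units; within the scatter) from compound 3 to compound 4, 1.1-fold (0.06 log units) apart, within the scatter of two such steps. On these two cores, which carry different side chains, the change therefore behaves alike, but since each step lies within the scatter, this does not show that the change truly weakens inhibition, and two cores do not establish a rule for the series.

The compounds shown leave open how a longer chain, such as ethyl or propyl, would compare with methyl or hydrogen on that nitrogen. They also leave open whether the change would behave alike on a core whose side chain ends in an amine or a carboxylic acid.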